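From Compound 1 to Compound 4: Losing One Fluoro

The compounds below may be only part of what the source reports. "The series", "measured", "known", "first", "only" and "open" are said of these compounds alone.

In a functional assay on DU-145 cells (Homo sapiens) for antiproliferative activity, read by MTT assay (on this read-out higher numbers stand for weaker inhibition and lower numbers for stronger inhibition), compound 1 (`Cc1nn2c(-c3nc4cc(Cl)c(F)cc4[nH]3)c(-c3ccc(F)cc3)nc2s1`) gives > 30000 nM, which is a limit and not a number. Compound 2 (`Cc1nn2c(-c3nc4cc(Cl)c(F)cc4[nH]3)c(-c3ccccc3)nc2s1`) gives > 30000 nM, also a limit. The series thus rests largely on (the limit of > 30000 nM in this assay, at which 2 of the 3 values shown sit). Compound 3 (`Cc1nn2c(-c3nc4cc(F)ccc4[nH]3)c(-c3ccccc3)nc2s1`) gives a measured 16900 nM. Compound 4 (`Cc1nn2c(-c3nc4cc(Cl)ccc4[nH]3)c(-c3ccc(F)cc3)nc2s1`) differs from compound 1 by hydrogen in place of fluoro on an aromatic carbon, ortho to a chloro group. For the measured compounds named here, the only measured step of this kind is a step that the two limits leave unreadable from compound 1 to compound 2, so it sets no size. Since compound 3 reads 16900 nM, a measurable number for compound 4 seems possible, and any expected change is small, towards stronger inhibition. The expected step is an at least 1.0-fold lower number from compound 1 to compound 4 (0.02 log units; that floor lies within the scatter). Compound 4 is estimated at 28000 nM, with an expected range of 12000 nM to 60000 nM.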

Compound 4, half-maximal inhibitory concentration: 14400 nM
Compound 4: the middle estimate sits 1.9-fold (0.29 log units) above what was measured; the range from low to high includes it.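

In this assay, hydrogen in place of fluoro on this aromatic carbon, ortho to a chloro group, now gives a readable result: an at least 2.0-fold lower number from compound 1 to compound 4 (0.31 log units; beyond the scatter). Compound 1 gives > 30000 nM, a limit, so this step has a floor and no exact size. Much of the series still rests on such a limit: the limit of > 30000 nM in this assay, at which 2 of the 4 values shown sit.

The compounds shown leave open how a group other than hydrogen or fluoro on this carbon, such as a methoxy group or an amine, would read. They also leave open whether the step holds when the chloro group is absent.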